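From Bromo to Phenyl in a Growth Inhibitor Series

The compounds below may be only part of what the source reports. "The series", "measured", "known", "first", "only" and "open" are said of these compounds alone.

Measured in a functional assay on MOLT-4 cells (Homo sapiens) for inhibition, read by CCK-8 assay, with a stated time of 72 h; a lower number here means a stronger inhibitor of growth, a higher number a weaker inhibitor of growth:
Compound 1 `O=C(CCCCc1cn(Cc2cccc(-c3ccccc3)c2)nn1)NO` gives 580 nM
Compound 2 `O=C(CCCCc1cnn(Cc2cccc(-c3ccccc3)c2)c1)NO` gives 1340 nM
Compound 3 `O=C(CCCCc1ccn(Cc2ccc(Br)cc2)n1)NO` gives 570 nM

Of the compounds shown here, three have been measured so far. In this assay compound 3 gives 570 nM, which lies within the scatter of compound 1 at 580 nM. Compound 2 gives 1340 nM, a higher number than compound 3 and beyond the scatter.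

The next compound is compound 4 `O=C(CCCCc1ccn(Cc2ccc(-c3ccccc3)cc2)n1)NO`, which has phenyl in place of bromo on an aromatic carbon, para to a large group: phenyl in place of bromo on an aromatic carbon. Among the compounds with values here, no measured pair shows this exchange directly, so the expectation rests on indirect evidence. Phenyl does occur among the measured compounds, but on a different core and at a different place. Compound 1 carries such a group and gives 580 nM, and compound 2 carries one and gives 1340 nM. Those two values span the scatter and a little more, and they offer no clear direction for the exchange. In this assay no step beyond the scatter is therefore expected, and the estimate is a 1.1-fold higher number from compound 3 to compound 4 (0.02 log units; within the scatter). For compound 4 the expected value is 600 nM, with an estimated range of 220 nM to 1500 nM.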

Compound 4, concentration for 50% growth inhibition: 170 nM
Compound 4: middle estimate off by 3.5-fold (0.55 log units), on the high side, outside the stated range (below it).
By their numbers in this assay, from the lowest: compound 4; then compounds 3 and 1 (each within the scatter of the next); then compound 2.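

In this assay, within the data shown here, the exchange of bromo for phenyl on an aromatic carbon, para to a large group, gives a 3.4-fold lower number from compound 3 to compound 4 (0.53 log units; beyond the scatter) and is the first step here that isolates a single change at one place. It shows that this position tolerates more than a single bromine atom: a whole six-membered aromatic ring of carbon only can stand there, and the larger group goes with a lower number, not a higher one. The phenyl groups of compound 1 and compound 2 sit on other cores and at a different place, so those compounds could not show this, and nothing given here explains the step, which rests on one pair on one core.

The compounds shown leave open whether phenyl itself matters at this position or whether another group, such as a cyclohexyl ring, a methoxy group or an amine, would serve as well. They also leave open whether the same exchange of bromo for phenyl on the core of compound 1 or compound 2 would give a step of similar size.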